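Fluorine on the fused ring of compound 2

The source may hold more compounds than are shown below. What is called first, only, known or untested is meant among the compounds shown, and "the series" means these compounds.

Compound 2 `COc1cc(N(C)CCN(C)C)c(NC(=O)/C=C\C(C)C)cc1Nc1nc(C)cc(-c2cn(C)c3ccccc23)n1` gives 3550 nM in a functional assay on HepG2 cells (Homo sapiens) for antiproliferative activity, read by MTT assay, with a stated time of 72 h (a higher number here means a weaker inhibitor, a lower number a stronger inhibitor), which places it second highest among the three measured compounds. Compound 1 `COc1cc(N(C)CCN(C)C)c(NC(=O)/C=C\C(C)C)cc1Nc1nccc(-c2cn(C)c3ccccc23)n1` lies nearest, giving 4390 nM, and the change a 1.2-fold lower number from compound 1 to compound 2 (0.09 log units; within the scatter) is a methyl in place of hydrogen on an aromatic carbon. Compound 3 `CCC/C=C\C(=O)Nc1cc(Nc2nc(C)cc(-c3cn(C)c4ccccc34)n2)c(OC)cc1N(C)CCN(C)C` lies furthest, giving 365 nM, reached by a 9.7-fold lower number from compound 2 to compound 3 (0.99 log units; beyond the scatter) through a propyl in place of isopropyl on the double-bonded chain.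

Compound 4 `COc1cc(N(C)CCN(C)C)c(NC(=O)/C=C\C(C)C)cc1Nc1nc(C)cc(-c2cn(C)c3ccc(F)cc23)n1` differs from compound 2 by fluoro in place of hydrogen on an aromatic carbon, on an aromatic carbon of a six-membered aromatic ring of carbon only, part of a fused system of two rings, so that 1-methyl-1H-indol-3-yl becomes 5-fluoro-1-methyl-1H-indol-3-yl. Of the measured steps only the aromatic substitution in a 1.2-fold lower number from compound 1 to compound 2 (0.09 log units; within the scatter) resembles this change, and it stayed within the scatter; the chain change behind a 9.7-fold lower number from compound 2 to compound 3 (0.99 log units; beyond the scatter) touches a different part of the molecule. Compound 4 is therefore expected to show a 1.2-fold lower number from compound 2 to compound 4 (0.07 log units; within the scatter), a step not beyond the scatter. The estimate for compound 4 is 3000 nM, with a range from 1000 nM to 9000 nM.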

Compound 4, half-maximal inhibitory concentration: 14000 nM
Compound 4: the middle estimate sits 4.7-fold (0.67 log units) below what was measured; the measured number lies above the stated range.
By their numbers in this assay, from the lowest: compound 3; then compounds 2 and 1 (each within the scatter of the next); then compound 4.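

In this assay the fluoro group gives a 3.9-fold higher number from compound 2 to compound 4 (0.60 log units; beyond the scatter) as the 1-methyl-1H-indol-3-yl group becomes 5-fluoro-1-methyl-1H-indol-3-yl, so a single heavy atom on this fused ring moves the number beyond the scatter. Within the data shown here, the only earlier step beyond the scatter, a 9.7-fold lower number from compound 2 to compound 3 (0.99 log units; beyond the scatter) on the chain, lowered the number, while this change on the ring raises it and shows that the number also responds to substitution on this part of the molecule. Nothing measured here explains this rise.

Whether the rise is specific to fluoro stays open, since chloro, methoxy and nitrile on this aromatic carbon are not among the compounds shown. As far as these compounds go, it is also open whether the same fluoro would raise the number in compound 3 with its propyl chain.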